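Phenyl for 4-fluorobenzyl on the aromatic ring nitrogen

This account rests on a few compounds, and the source may have more. Where it says the series, first, only, none or still open, it means among the compounds named here.

Measured so far in a functional assay on cells (Platelet, Homo sapiens) for inhibition; a higher number here means a weaker inhibitor, a lower number a stronger inhibitor:
compound 1 `CCOC(=O)c1cccc(-c2n[nH]c3ccccc23)c1`, 5650 nM
compound 2 `CCOC(=O)c1ccc(-c2nn(Cc3ccc(F)cc3)c3ccccc23)cc1`, 190 nM
compound 3 `CNC(=O)c1ccc(-c2nn(Cc3ccccc3)c3ccccc23)cc1`, reported only as a limit, > 10000 nM

Compound 2 holds the lowest of the two numbers given; compound 1 sits at a higher value, a gap beyond the usual scatter. For compound 3 the value is the limit of > 10000 nM in this assay, at which 1 of the 3 values shown sits, so it gives no number to compare.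

Compound 4 `CCOC(=O)c1ccc(-c2nn(-c3ccccc3)c3ccccc23)cc1` is not yet measured. It differs from compound 2 in one place: phenyl in place of 4-fluorobenzyl on an aromatic nitrogen. Among the measured compounds shown here, compound 1, the only other compound with the ethyl ester, carries no group on that nitrogen at all, so the data give no direct guide to what phenyl does there. The step is expected to go toward a weaker inhibitor, a 7.9-fold higher number from compound 2 to compound 4 (0.90 log units; beyond the scatter), beyond the scatter. In this assay compound 4 is expected to give about 1500 nM, with a range from 300 nM to 8000 nM.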

Compound 4, half-maximal inhibitory concentration: 2640 nM
For compound 4 the middle estimate is 1.8-fold (0.25 log units) below the measured one; the range from low to high includes it.
By their numbers in this assay, from the lowest: compound 2; then compound 4; then compound 1. At a limit, above all of these: compound 3.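

In this assay the group on the aromatic nitrogen clearly matters within the ethyl ester compounds: a 14-fold higher number from compound 2 to compound 4 (1.14 log units; beyond the scatter). Among the compounds shown here, this is the first change confined to this position, and phenyl does not keep the level of compound 2. No measurement shown bears on the cause of this step.

Going by these compounds, the step removes both the fluorine and the carbon linking the ring to the nitrogen, so their separate contributions remain open. Also open, on these data alone, is how a longer chain, such as 2-phenylethyl, would behave on that nitrogen.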